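The source may hold more compounds than are shown below. What is called first, only, known or untested is meant among the compounds shown, and "the series" means these compounds.

Going by the values given here, in a functional assay on WEHI231 cells (Mus musculus) for inhibition, with a stated time of 48 h (on this read-out lower numbers stand for an effect already at smaller amounts and higher numbers for an effect only at larger amounts of compound), compound 1 (`C#Cc1ccc(C#Cc2ccc(C(=O)OCC3(CO)CC(=C(C)C)C(=O)O3)cc2)cc1`) gives 3000 nM and compound 2 (`C#Cc1ccc(C#Cc2ccc(C#Cc3ccc(C(=O)OCC4(CO)CC(=C(C)C)C(=O)O4)cc3)cc2)cc1`) gives 400 nM, so compound 2 holds the lower of the two numbers measured so far. Compound 3 (`COc1ccc(C#Cc2ccc(C#Cc3ccc(C(=O)OCC4(CO)CC(=C(C)C)C(=O)O4)cc3)cc2)cc1`) differs from compound 2 in one place, with methoxy in place of ethynyl on an aromatic carbon. Among the compounds with values here, only one measured step bears on this change, and only indirectly: a 7.5-fold lower number from compound 1 to compound 2 (0.88 log units; beyond the scatter), on putting 4-ethynylphenyl in place of hydrogen on a triple-bonded carbon. Within the data shown here, compound 3 carries 4-methoxyphenyl there instead, and no measured step shows what replacing the ethynyl itself does. A small change toward a higher number is therefore expected in this assay, probably not beyond the scatter, and the expected step is a 1.5-fold higher number from compound 2 to compound 3 (0.18 log units; within the scatter). For compound 3 the estimate is 600 nM, within a range of 150 nM to 2000 nM.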

Compound 3, half-maximal effective concentration: 430 nM
Compound 3: the middle estimate sits 1.4-fold (0.14 log units) above what was measured; the measured number falls inside the stated range.
By their numbers in this assay, from the lowest: compounds 2 and 3 (each within the scatter of the next); then compound 1.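

In this assay, methoxy in place of ethynyl on the aromatic carbon para to a large group gives a 1.1-fold higher number from compound 2 to compound 3 (0.03 log units; within the scatter) and so leaves the read-out where it was, which shows that this position accepts either group without a step beyond the scatter. Read from the other side, 4-methoxyphenyl in place of hydrogen on a triple-bonded carbon gives a 7.0-fold lower number from compound 1 to compound 3 (0.84 log units; beyond the scatter) as its step, so the lower number that came with 4-ethynylphenyl does not rest on the ethynyl itself. Nothing given here accounts for why these two groups read alike.

As far as these compounds go, whether this tolerance extends to an amine, a carboxylic acid or a longer chain at this position remains open. From the compounds shown here alone, it is also open whether the unsubstituted phenyl would read the same.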